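Moving a Trifluoromethyl Group on a Sulfonyl Aryl Ring

The source may report more compounds than this note shows. Statements on the series, on what has been measured and on what is new or still open speak of the compounds shown alone.

Compound 1 `Cc1ccc(-c2ccc(C3(C)CC(S(=O)(=O)c4ccc(F)cc4)=C(c4ccc(/C(N)=N\O)cc4)O3)cc2)cc1` gives 13700 nM in an ADME assay on HepG2 cells (Homo sapiens) for cytotoxicity, read by MTT assay, with a stated time of 72 h; a lower number here means that less compound is tolerated, a higher number that more compound is tolerated.
Compound 2 `CC1(Cc2ccccc2)CC(S(=O)(=O)c2cccc(C(F)(F)F)c2)=C(c2ccc(/C(N)=N\O)cc2)O1` gives 33400 nM in this assay.

Only these two compounds have been measured, and they differ from each other in several places at once, so no single change can be followed between them. On the numbers shown, compound 2 stands highest, meaning that it is the better tolerated of the two; compound 1 gives the lower number, and that gap lies beyond the usual scatter of repeated measurements.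

Compound 3 `CC1(Cc2ccccc2)CC(S(=O)(=O)c2ccccc2C(F)(F)F)=C(c2ccc(/C(N)=N\O)cc2)O1` is the next compound and differs from compound 2 in one place only: 2-(trifluoromethyl)phenyl in place of 3-(trifluoromethyl)phenyl on a sulfonyl sulfur. The atoms are the same and only their arrangement on the ring changes. Among the measured compounds shown here, there is no measured pair in this set that shows how such a rearrangement plays out, so the expectation rests on compound 2 alone. The step of a 1.1-fold lower number from compound 2 to compound 3 (0.05 log units; within the scatter) is expected to be small, with no clear direction and probably not beyond the scatter. Compound 3 is therefore expected to give about 30000 nM, within a range from 12000 nM to 75000 nM.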

Compound 3, half-maximal cytotoxic concentration: 57500 nM
The estimate for compound 3 lay 1.9-fold (0.28 log units) below the measured number; measured number inside the range.
By their numbers in this assay, from the lowest: compound 1; then compounds 2 and 3 (each within the scatter of the next).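

Among the compounds shown here, compound 2 and compound 3 form the first pair here that differs in one place, so a single change can finally be followed: 2-(trifluoromethyl)phenyl in place of 3-(trifluoromethyl)phenyl on a sulfonyl sulfur gives a 1.7-fold higher number from compound 2 to compound 3 (0.24 log units; within the scatter) in this assay. The same atoms are kept and only their arrangement on the ring changes, and in this pair that rearrangement stays within what repeat measurements would be expected to show, so the two compounds cannot be told apart on this read-out. No measurement shown here offers an explanation for this result, and with a single pair it cannot be called a general rule for this position.

Still open, as far as these compounds go, is how tolerance responds when the trifluoromethyl group gives way to a different group on this ring, such as a methoxy group, an amine or a carboxylic acid, or when the ring carries no such group at all. Also open, from the compounds shown here alone, is whether the same rearrangement would behave alike on the core of compound 1, which differs from compound 2 in several places at once.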